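The source may hold more compounds than are shown below. What is called first, only, known or untested is meant among the compounds shown, and "the series" means these compounds.

Measured compounds:

compound 1, `CN(C)CCn1cnnc1-c1cc(Oc2ccc(NC(=O)N/N=C/c3cccc(Br)c3)cc2F)ccn1` — in a functional assay on U-87MG ATCC cells (Homo sapiens) for cytotoxicity, read by MTT assay, with a stated time of 72 h (a higher number here means a weaker inhibitor, a lower number a stronger inhibitor), compound 1 gives 830 nM.
compound 2, `CN(C)CCn1cnnc1-c1cc(Oc2ccc(NC(=O)N/N=C/c3cccc(O)c3)cc2F)ccn1` — compound 2 gives > 100000 nM, a limit of the assay.
compound 3, `CN(C)CCn1cnnc1-c1cc(Oc2ccc(NC(=O)N/N=C/c3ccc(O)c(F)c3)cc2F)ccn1` — compound 3 gives > 100000 nM, also a limit of the assay.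

Compound 3 therefore stands at the top of the measured range, and the limit is shared: the limit of > 100000 nM in this assay, at which 2 of the 3 values shown sit. Where compound 1 sits well below that limit, both compounds carrying a hydroxy on the ring attached to the carbon with a double bond to nitrogen reach it.

The next compound, compound 4, is `CN(C)CCn1cnnc1-c1cc(Oc2ccc(NC(=O)N/N=C/c3ccc(O)c(O)c3)cc2F)ccn1`. Relative to compound 3 the change is hydroxy in place of fluoro on an aromatic carbon.

Going by the values given here, the steps that bear on this are an at least 120-fold higher number from compound 1 to compound 2 (2.08 log units; beyond the scatter) and an at least 120-fold higher number from compound 1 to compound 3 (2.08 log units; beyond the scatter), both large weakenings once a hydroxy is present; the direct comparison a step that the two limits leave unreadable from compound 2 to compound 3 cannot be read. Adding a second hydroxy to a compound already at the limit gives no ground to expect a return below it. The step that the limit leaves unreadable from compound 3 to compound 4 is expected to stay unreadable. Compound 4 is expected to give 150000 nM, within 40000 nM to 600000 nM, most likely reported again as a limit.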

Compound 4, half-maximal inhibitory concentration: > 100000 nM
Compound 4: a limit, no number; the forecaster's own chance of this, stated with the estimate: 85%; the middle value does not contradict the limit.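

In this assay compound 4 gives > 100000 nM as a limit of the assay, so hydroxy in place of the fluoro, ortho to a hydroxy group, brings no reading back into range. The 3,4-dihydroxyphenyl in place of 3-bromophenyl gives an at least 120-fold higher number from compound 1 to compound 4 (2.08 log units; beyond the scatter) and the steps among compound 2, compound 3 and compound 4 cannot be read. A third hydroxy-bearing compound thus joins the same ceiling, with compound 1 alone still giving a number: the limit of > 100000 nM in this assay, at which 3 of the 4 values shown sit.

From the compounds shown here alone, whether a methoxy or an amine in place of the hydroxy on this ring would stay at that limit or return toward compound 1 remains open. Any order among the three hydroxy-bearing compounds also remains open, as all three are limits.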